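Aryl variation on a five-membered ring of three nitrogens

The source may hold more compounds than are shown below. What is called first, only, known or untested is meant among the compounds shown, and "the series" means these compounds.

Compound 1 `N#CC1=C(N)Oc2c(N)cc3nc4ccccc4nc3c2C12C(=O)N(Cc1cnnn1-c1ccc(F)cc1)c1ccccc12`, compound 2 `Cc1ccc(-n2nncc2CN2C(=O)C3(C(C#N)=C(N)Oc4c(N)cc5nc6ccccc6nc5c43)c3ccccc32)cc1C` and compound 3 `Cc1ccc(C)c(-n2nncc2CN2C(=O)C3(C(C#N)=C(N)Oc4c(N)cc5nc6ccccc6nc5c43)c3ccccc32)c1` share one core and differ only in the aryl group on an aromatic nitrogen of the five-membered aromatic ring with 3 nitrogen. In a functional assay on HCT-116 cells (Homo sapiens) for antiproliferative activity, read by MTT assay, with a stated time of 48 h (a higher number here means a weaker inhibitor, a lower number a stronger inhibitor), compound 1 gives > 50000 nM, which is a limit of the assay and not a number. Compound 2 gives > 50000 nM, again a limit rather than a number. Compound 3 gives > 50000 nM, also a limit. Compound 3 therefore stands where every measured member stands, at the limit of > 50000 nM in this assay, at which 3 of the 3 values shown sit. The steps a step that the two limits leave unreadable from compound 1 to compound 2, a step that the two limits leave unreadable from compound 1 to compound 3 and a step that the two limits leave unreadable from compound 2 to compound 3 have no readable size; both ends of each are limits.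

Going by the values given here, compound 4 `N#CC1=C(N)Oc2c(N)cc3nc4ccccc4nc3c2C12C(=O)N(Cc1cnnn1-c1c(Cl)cc(Cl)cc1Cl)c1ccccc12` is the next member. 2,4,6-trichlorophenyl in place of 2,5-dimethylphenyl on an aromatic nitrogen No measured step bears on this change with a readable size: the three aryl variations so far, 4-fluorophenyl, 3,4-dimethylphenyl and 2,5-dimethylphenyl, all left the compounds at the limit. The expectation is that compound 4 remains there as well, the step that the limit leaves unreadable from compound 3 to compound 4 being expected to stay within the scatter. Compound 4 is estimated at 60000 nM, with a range from 20000 nM to 200000 nM, most probably reported as a limit only.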

Compound 4, half-maximal inhibitory concentration: 12100 nM
Beside the measured number, compound 4's estimate is 5.0-fold (0.70 log units) above it; the measured number lies below the stated range.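

With 2,4,6-trichlorophenyl on the aromatic nitrogen, this position proves able to bring the series off the limit in this assay, giving an at least 4.1-fold lower number from compound 3 to compound 4 (0.61 log units; beyond the scatter), an at least 4.1-fold lower number from compound 2 to compound 4 (0.61 log units; beyond the scatter) and an at least 4.1-fold lower number from compound 1 to compound 4 (0.61 log units; beyond the scatter). Each of these sizes is only a bound, with one end a limit, and the steps among compound 1, compound 2 and compound 3 cannot be read, so those three aryl groups cannot be ordered against one another. Compound 4 is the only member shown with a measured number, and the other three all remain at one limit: the limit of > 50000 nM in this assay, at which 3 of the 4 values shown sit.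

The change from 2,5-dimethylphenyl replaces two methyl groups with three chlorine atoms and alters the substitution pattern in the same step, so the compounds shown leave open whether all three chlorine atoms are needed or a phenyl with a single chlorine would also leave the limit. Also open, on these data alone, is whether a phenyl carrying a methoxy group, an amine or a carboxylic acid would give a measurable number in this assay.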